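The compounds below may be only part of what the source reports. "The series", "measured", "known", "first", "only" and "open" are said of these compounds alone.

Working notes on the series. In a functional assay on A549 cells (Homo sapiens) for antiproliferative activity, read by MTT assay, with a stated time of 72 h (on this read-out higher numbers stand for weaker inhibition and lower numbers for stronger inhibition), compound 1 `COc1ccc(-n2c(=O)c(C(=O)Nc3ccc(Oc4ccnc5[nH]ccc45)cc3)cc3cccnc32)cc1` gives 930 nM, compound 2 `O=C(Nc1ccc(Oc2ccnc3[nH]ccc23)cc1)c1cc2cccnc2n(-c2ccc(F)c(Cl)c2)c1=O` gives 680 nM and compound 3 `O=C(Nc1ccc(Oc2ccnc3[nH]ccc23)cc1)c1cc2cccnc2n(-c2ccc(C(F)(F)F)cc2Cl)c1=O` gives 3230 nM. Compound 3 stands highest of the three numbers: the step of a 3.5-fold higher number from compound 1 to compound 3 (0.54 log units; beyond the scatter) and the step of a 4.8-fold higher number from compound 2 to compound 3 (0.68 log units; beyond the scatter) are both beyond the scatter, whereas the step of a 1.4-fold lower number from compound 1 to compound 2 (0.14 log units; within the scatter) lies within it. Every measured step exchanges the aryl group on the aromatic nitrogen of the six-membered part of the shared core, and the fused bicyclic ether substituent is kept unchanged throughout.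

Compound 4 `Cn1ccc2c(Oc3ccc(NC(=O)c4cc5cccnc5n(-c5ccc(C(F)(F)F)cc5Cl)c4=O)cc3)ccnc21` differs from compound 3 by methyl in place of hydrogen on an aromatic nitrogen, on an aromatic nitrogen of a five-membered aromatic ring with 1 nitrogen, part of a fused system of two rings. Going by the values given here, no measured step touches this part of the molecule, so none bears on the change, and the measured steps give no size or direction to carry over. With no comparison to draw on, the expected step in this assay is set close to none beyond the scatter, and the range is wide. The step expected is a 1.4-fold higher number from compound 3 to compound 4 (0.14 log units; within the scatter). In this assay compound 4 is expected to give 4500 nM, with a range from 1500 nM to 18000 nM.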

Compound 4, half-maximal inhibitory concentration: 8250 nM
Compound 4: middle estimate off by 1.8-fold (0.26 log units), on the low side; the range from low to high includes it.
By their numbers in this assay, from the lowest: compounds 2 and 1 (each within the scatter of the next); then compound 3; then compound 4.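

Going by these compounds alone, the fused bicyclic part stayed unchanged in every earlier step, so this is the first reading at this site: in this assay, methyl in place of hydrogen on the aromatic nitrogen of the five-membered aromatic ring gives a 2.6-fold higher number from compound 3 to compound 4 (0.41 log units; beyond the scatter), a step beyond the scatter towards weaker inhibition. The position therefore responds to substitution, and the number moves here as well as at the aryl group on the shared core, where the exchange gave a 3.5-fold higher number from compound 1 to compound 3 (0.54 log units; beyond the scatter), also modest and beyond the scatter. No measurement on hand bears on why the number rises with this change.

Going by these compounds, the reading rests on a single pair carrying 2-chloro-4-(trifluoromethyl)phenyl on the core, so it remains open whether methyl on this nitrogen would shift the number in the same direction and by a similar size with 3-chloro-4-fluorophenyl or 4-methoxyphenyl in that place. On these data alone, it also remains open how this nitrogen would respond to an ethyl group or to a longer chain ending in an amine or a carboxylic acid.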